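The source may hold more compounds than are shown below. What is called first, only, known or untested is meant among the compounds shown, and "the series" means these compounds.

Measured so far: compound 1 `CCCCCCOc1cccc(O)c1C(=O)/C=C/c1ccc(O)cc1`, compound 2 `CC(C)=CCOc1cccc(O)c1C(=O)/C=C/c1ccc(O)cc1` and compound 3 `O=C(/C=C/c1ccc(O)cc1)c1c(O)cccc1OCCC1CCCC1`. In a functional assay on PC-3 cells (Homo sapiens) for antiproliferative activity, read by sulforhodamine B assay (on this read-out lower numbers stand for stronger inhibition of growth and higher numbers for weaker inhibition of growth), compound 1 gives only a limit, > 30000 nM. Compound 2 likewise gives only a limit, > 30000 nM. Going by the values given here, compound 3 gives 3480 nM, the only number among the three. Compounds 1 and 2 sit at the limit of > 30000 nM in this assay, at which 2 of the 3 values shown sit. Compound 4 `O=C(/C=C/c1ccc(O)cc1)c1c(O)cccc1OCC1CCCC1` differs from compound 3 by cyclopentyl in place of cyclopentylmethyl on a saturated chain carbon bound to an oxygen on an aromatic ring. Among the compounds with values here, the steps that bear on this change are an at least 8.6-fold lower number from compound 1 to compound 3 (0.93 log units; beyond the scatter) and an at least 8.6-fold lower number from compound 2 to compound 3 (0.93 log units; beyond the scatter), both gains on moving to the 2-cyclopentylethoxy chain. Compound 4 keeps the ring on a shorter chain, a move neither step tests directly, so a step of a 1.4-fold higher number from compound 3 to compound 4 (0.16 log units; within the scatter) is expected, within or barely beyond the scatter. Compound 4 is therefore estimated at 5000 nM, between 1500 nM and 15000 nM.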

Compound 4, concentration for 50% growth inhibition: 3040 nM
Beside the measured number, compound 4's estimate is 1.6-fold (0.22 log units) above it, and the stated range covers the measured number.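

In this assay, cyclopentyl in place of cyclopentylmethyl gives a 1.1-fold lower number from compound 3 to compound 4 (0.06 log units; within the scatter), so these two chain lengths cannot be told apart at this position. The gain seen with the ring holds on the shorter chain, with an at least 9.8-fold lower number from compound 2 to compound 4 (0.99 log units; beyond the scatter) and an at least 9.8-fold lower number from compound 1 to compound 4 (0.99 log units; beyond the scatter). The true size of these two gains stays unknown, as compounds 1 and 2 give limits and not numbers: the limit of > 30000 nM in this assay, at which 2 of the 4 values shown sit.

Going by these compounds, whether a cyclohexyl or phenyl ring would serve as well as cyclopentyl stays open. So does the effect of a longer chain carrying the ring, or of the ring bound directly to the oxygen.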